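From isopropyl to benzyl on an oxygen

The source may hold more compounds than are shown below. What is called first, only, known or untested is meant among the compounds shown, and "the series" means these compounds.

- compound 1 `CO/N=C(/C#N)C(=O)NCC1=NOC(C)(C)C1`: > 100 ug/mL
- compound 2 `CC(C)O/N=C(\C#N)C(=O)NCC1=NOC(C(C)(C)C)C1`: > 100 ug/mL

Among the measured compounds shown here, the only readings so far come from a functional assay on MDBK cells (Bos taurus) for cytotoxicity; a lower number here means that less compound is tolerated, a higher number that more compound is tolerated. In this assay, compound 2 gives > 100 ug/mL, which is a limit of the assay and not a number. Compound 1 gives > 100 ug/mL, which is also a limit. The whole picture so far is therefore (the limit of > 100 ug/mL in this assay, at which 2 of the 2 values shown sit).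

Compound 3 `CC(C)(C)C1CC(CNC(=O)/C(C#N)=N/OCc2ccccc2)=NO1` keeps the rest of compound 2 and changes one group: benzyl in place of isopropyl on an oxygen. In words, benzyl takes the place of isopropyl on an oxygen. For the measured compounds named here, no pair of measured compounds differs in one place only, so the data hold no direct measure of what such a swap does.

No step beyond the usual scatter is expected in this assay, in either direction. This expectation rests on compound 2, which stands at the limit of > 100 ug/mL. The estimated change is a number no higher from compound 2 to compound 3 (the limit leaves the size open). For compound 3, the estimated value is 100 ug/mL, with an expected range of 50 ug/mL to 200 ug/mL.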

Compound 3, half-maximal cytotoxic concentration: 100 ug/mL
Estimate against measurement, compound 3: no gap at the digits printed, within the range that was stated.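

In this assay, among the compounds shown here, compound 3 gives 100 ug/mL, the first reading that is a number rather than a limit. Compound 2 gives > 100 ug/mL, which is a limit of the assay. The step is a number no higher from compound 2 to compound 3 (the limit leaves the size open), so putting benzyl, with its six-membered aromatic ring, in place of isopropyl on this oxygen yields a compound with a definite place on the scale, but how far the swap shifts tolerance stays unknown, and the series still sits mostly at one edge of the scale: the limit of > 100 ug/mL in this assay, at which 2 of the 3 values shown sit.

Still open, going by these compounds, is how tolerance responds to other groups on this oxygen, such as a longer chain like n-octyl, a benzyl ring carrying a chlorine, or a chain ending in an amine or a carboxylic acid. With cell tolerance as the only read-out shown, the compounds also leave open whether the swap from isopropyl to benzyl changes anything else about how these compounds behave.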